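This account rests on a few compounds, and the source may have more. Where it says the series, first, only, none or still open, it means among the compounds named here.

Measured in a functional assay on K562 cells (Homo sapiens) for cytotoxicity, read by MTT assay, with a stated time of 48 h; on this read-out higher numbers stand for weaker inhibition and lower numbers for stronger inhibition:
- compound 1 `CCN1C(=O)C(=O)c2cc(/C=C/C(=O)OC)ccc21`: 170 nM
- compound 2 `CC(C)(C)OC(=O)/C=C/c1ccc2c(c1)C(=O)C(=O)N2Cc1ccc(Br)cc1`: 290 nM
- compound 3 `COc1ccc(CN2C(=O)C(=O)c3cc(/C=C/C(=O)OC(C)(C)C)ccc32)cc1`: 50 nM

Compound 2 and compound 1 lie within the scatter of each other, and together they sit at the upper end of these three numbers. Compound 3 lies beyond the scatter from compound 2.

Next in the series is compound 4 `CCCCOC(=O)/C=C/c1ccc2c(c1)C(=O)C(=O)N2Cc1ccc(Br)cc1`, not yet measured. The change is butyl in place of tert-butyl on an oxygen next to a carbonyl group, with the same atoms joined differently.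

Within the data shown here, the only measured single-place step is a 5.8-fold lower number from compound 2 to compound 3 (0.76 log units; beyond the scatter). It is a modest step, but it is methoxy in place of bromo on an aromatic carbon, so it does not speak to this change. Among the measured compounds shown here, compound 1 differs from compound 2 in more than one place, and no measured pair isolates tert-butyl against butyl.

No shift beyond the scatter is therefore expected in this assay. The expected change is a 1.2-fold lower number from compound 2 to compound 4 (0.06 log units; within the scatter). The estimate for compound 4 is 250 nM, with an expected range of 90 nM to 700 nM.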

Compound 4, half-maximal inhibitory concentration: 150 nM
Compound 4: middle estimate off by 1.7-fold (0.22 log units), on the high side; the range from low to high includes it.
By their numbers in this assay, from the lowest: compound 3; then compounds 4, 1 and 2 (each within the scatter of the next).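

In this assay, among these compounds, the pair of compounds 2 and 4 is the first to isolate this change, and butyl in place of tert-butyl on an oxygen next to a carbonyl group gives a 1.9-fold lower number from compound 2 to compound 4 (0.29 log units; within the scatter). With the rest of the structure held constant, joining the same atoms differently at this place therefore produces no shift beyond the scatter, although this rests on a single pair carrying the bromo substituent. Nothing available gives a reason for the size of this step.

As far as these compounds go, whether butyl and tert-butyl also match when methoxy replaces bromo, as in compound 3, remains open. Also open, from the compounds shown here alone, is how this place responds to a more different group, such as a longer chain like octyl, a benzyl group, or a carboxylic acid in place of the ester.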